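Chloroacetyl urea in place of chloropropyl urea on the alcohol series

The source may hold more compounds than are shown below. What is called first, only, known or untested is meant among the compounds shown, and "the series" means these compounds.

Measured compounds:
compound 1 `CCCCC(O)c1cccc(NC(=O)NCCCCl)c1`, 19000 nM
compound 2 `CCCCC(OC)c1cccc(NC(=O)NCCCCl)c1`, 56000 nM
compound 3 `CC(C)(C)c1ccc(CNC(=O)NC(=O)CCl)cc1`, 7100 nM

In a functional assay on HT-29 cells (Homo sapiens) for antiproliferative activity, with a stated time of 48 h (on this read-out higher numbers stand for weaker inhibition and lower numbers for stronger inhibition), compound 1 gives 19000 nM and stands second highest of the three numbers. Compound 3 gives 7100 nM, a lower number, and compound 2 gives 56000 nM, the highest number. Going by the values given here, the only single-point step among the measured compounds, a 2.9-fold higher number from compound 1 to compound 2 (0.47 log units; beyond the scatter), concerns the oxygen on the saturated carbon and does not touch the urea end.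

Compound 4 `CCCCC(O)c1cccc(NC(=O)NC(=O)CCl)c1` has not been measured. It differs from compound 1 by (chloromethyl)carbonyl in place of 3-chloropropyl on an amide-type nitrogen. Among the compounds with values here, no measured pair isolates this change. Compound 3 carries the (chloromethyl)carbonyl group on its urea but also differs from compound 1 in the core and its substituent, so its value shows only that an acylurea of this kind can give a lower number than compound 1 in this assay, not how much of that comes from the urea end.

On that basis a modest move to a lower number is expected, with wide uncertainty, as a 1.9-fold lower number from compound 1 to compound 4 (0.28 log units; within the scatter). Compound 4 is estimated at 10000 nM in this assay, within 3000 nM to 30000 nM.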

Compound 4, half-maximal inhibitory concentration: 10000 nM
Compound 4: the middle estimate sits on the measured number at the digits printed; low and high end bracket the measured number.
By their numbers in this assay, from the lowest: compounds 3, 4 and 1 (each within the scatter of the next, the first and the last beyond it); then compound 2.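

In this assay, going by these compounds alone, the pair of compound 1 and compound 4 isolates the urea end for the first time, on a shared core and with the alcohol kept in place, and it gives a 1.9-fold lower number from compound 1 to compound 4 (0.28 log units; within the scatter) as the reading for (chloromethyl)carbonyl in place of 3-chloropropyl on the amide-type nitrogen. On this core, then, the two groups cannot be told apart in this read-out, even though the exchange adds a carbonyl and a hydrogen-bond acceptor while the heavy-atom count of the group stays the same. No measurement at hand bears on why the two groups read alike.

Still open, on these data alone, is whether this reading holds on other parts of the series: the methyl ether step, a 2.9-fold higher number from compound 1 to compound 2 (0.47 log units; beyond the scatter), may or may not repeat when the urea carries (chloromethyl)carbonyl, and the core of compound 3 offers no matched partner for this exchange. Also open, as far as these compounds go, is what the chlorine contributes at this position, which a plain acetyl group, a longer chain ending in chlorine or an amine in place of the chlorine could test.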